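Methyl in place of hydrogen on compound 2

A few compounds are considered here, and "the series" means these few. Any claim that something is new, unique, unknown or untested is made for them only; others in the source may bear on it.

Compound 1 `CC#C[C@@H](CC(=O)O)c1ccc(OC[C@H]2COc3ccc(Cl)cc3O2)cc1`: 25.7 h
Compound 2 `CC#C[C@@H](CC(=O)O)c1ccc(OC[C@H]2COc3ccccc3O2)cc1`: 3.14 h

In an ADME assay on the whole organism (strain Sprague-Dawley) for metabolic stability, with Rattus norvegicus as the target, read by LC-MS, at a dose of 10 mg/kg by the oral route (a lower number here means that the compound disappears faster, a higher number that the compound lasts longer), compound 2 stands lowest of the two measured compounds at 3.14 h, while compound 1 reaches 25.7 h. Compound 3 `CC#C[C@@H](CC(=O)O)c1ccc(OC[C@H]2COc3ccc(C)cc3O2)cc1` differs from compound 2 by methyl in place of hydrogen on an aromatic carbon. Among the measured compounds shown here, one measured step bears on that carbon, where hydrogen replaces chloro, and it is sizeable: an 8.2-fold lower number from compound 1 to compound 2 (0.91 log units; beyond the scatter). Methyl is not chloro, and a single pair is thin evidence. On the strength of an 8.2-fold lower number from compound 1 to compound 2 (0.91 log units; beyond the scatter), a smaller change in the opposite direction is therefore expected, with the number rising rather than falling. The expected step is a 2.5-fold higher number from compound 2 to compound 3 (0.41 log units; beyond the scatter). In this assay, compound 3 is estimated at 8 h, with an expected range from 3 h to 22 h.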

Compound 3, half-life: 1.79 h
For compound 3 the middle estimate is 4.5-fold (0.65 log units) above the measured one; measured number outside the range, below it.
By their numbers in this assay, from the lowest: compounds 3 and 2 (each within the scatter of the next); then compound 1.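

In this assay a methyl on this aromatic carbon does not carry the effect of chloro: the methyl compound cannot be told apart from the hydrogen compound (a 1.8-fold lower number from compound 2 to compound 3 (0.24 log units; within the scatter)), while replacing chloro with methyl costs as much as removing it, or more (a 14-fold lower number from compound 1 to compound 3 (1.16 log units; beyond the scatter)). Among the three groups shown at this place, only chloro stands apart, so the long half-life of compound 1 does not come with just any group added to this carbon. Nothing measured here explains why chloro and methyl part ways.

On these data alone, whether fluoro, bromo, methoxy or a nitrile on this carbon would side with chloro or with hydrogen and methyl stays open. So does whether chloro would give the same result on another carbon of this ring.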